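Anilino substitution in a shared-core antiproliferative series

A few compounds are considered here, and "the series" means these few. Any claim that something is new, unique, unknown or untested is made for them only; others in the source may bear on it.

compound 1 `COc1cc2ncnc(Nc3cccc(F)c3)c2cc1OCCCCC(=O)Nc1ccc(S(N)(=O)=O)cc1`: > 40000 nM
compound 2 `COc1cc2ncnc(Nc3ccc(Cl)cc3)c2cc1OCCCCC(=O)Nc1ccc(S(N)(=O)=O)cc1`: > 40000 nM

In a functional assay on A549 cells (Homo sapiens) for antiproliferative activity, read by MTT assay, with a stated time of 72 h (a lower number here means a stronger inhibitor, a higher number a weaker inhibitor), compound 1 gives only a limit, > 40000 nM. Compound 2 likewise gives only a limit in this assay, > 40000 nM. The step that the two limits leave unreadable from compound 1 to compound 2 is therefore unreadable, and compound 2 stands at the limit together with the other value shown, as the limit of > 40000 nM in this assay, at which 2 of the 2 values shown sit, records. Compound 3 `COc1cc2ncnc(Nc3ccc(C(F)(F)F)cc3)c2cc1OCCCCC(=O)Nc1ccc(S(N)(=O)=O)cc1` differs from compound 2 by trifluoromethyl in place of chloro on an aromatic carbon. For the measured compounds named here, no measured step bears on this change, since neither value shown is a number. Compound 3 is expected to remain at the limit in this assay, so a step that the limit leaves unreadable from compound 2 to compound 3 is expected to be unreadable. The estimate for compound 3 is 60000 nM, between 20000 nM and 200000 nM.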

Compound 3, half-maximal inhibitory concentration: 14800 nM
Estimate against measurement, compound 3: 4.1-fold (0.61 log units) above; measured number outside the range, below it.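

In this assay, compound 3 gives the first readable number among the compounds shown. Trifluoromethyl in place of chloro at this site on the aromatic ring gives an at least 2.7-fold lower number from compound 2 to compound 3 (0.43 log units; beyond the scatter), and the change from 3-fluorophenyl to 4-(trifluoromethyl)phenyl gives an at least 2.7-fold lower number from compound 1 to compound 3 (0.43 log units; beyond the scatter). The step between compound 1 and compound 2 cannot be read, so only compound 3 shows that a change on this ring can bring the series off the limit: the limit of > 40000 nM in this assay, at which 2 of the 3 values shown sit.

Open, going by these compounds, is how a nitrile or an amine in the same place would read. Also open, on these data alone, is whether trifluoromethyl on the other ring position occupied in compound 1 would give a number.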